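From propanoyl to acetyl in compound 1

The compounds below may be only part of what the source reports. "The series", "measured", "known", "first", "only" and "open" are said of these compounds alone.

Compound 1 `CCC(=O)c1ccc(OCCCCOc2cc(C(=O)O)ccc2OC)c(C)c1O` carries a propanoyl group on one ring and a carboxylic acid on the other. In an assay on HEK293 cells for positive allosteric modulation of metabotropic glutamate receptor 3 (Rattus norvegicus), read by thallium flux, with a stated time of 2.5 min (on this read-out higher numbers stand for larger maximal responses and lower numbers for smaller maximal responses), compound 1 gives 62.5%, the second highest of the three numbers recorded. Compound 2 `CCC(=O)c1ccc(OCCCCOc2cccc(C(=O)O)c2C)c(C)c1O` gives 16.3% and compound 3 `Cc1c(OCCCCOc2ccc(C(=O)CC(C)(C)C)c(O)c2C)cccc1C(=O)O` gives 109%; compound 1 stands beyond the scatter from each, lower than compound 3 and higher than compound 2.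

Compound 4 `COc1ccc(C(=O)O)cc1OCCCCOc1ccc(C(C)=O)c(O)c1C` is the acetyl counterpart of compound 1: hydrogen in place of methyl on a saturated chain carbon bound to a carbonyl carbon. Among the measured compounds shown here, the only measured step at the same place runs the other way, a number 92.7 percentage points higher from compound 2 to compound 3 (beyond the scatter), a large gain on going to the bulkier group. That step sits on the core of compound 2, not on that of compound 1, so it transfers only loosely, and methyl to hydrogen is a smaller change than methyl to tert-butyl. Read in that light, shortening the chain at this place should lower the maximal response. For compound 4 a downward step is expected, a number 17.5 percentage points lower from compound 1 to compound 4 (beyond the scatter), beyond the scatter but well short of the measured step. Compound 4 is estimated at 45%, with a range from 20% to 75%.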

Compound 4, largest response reached (reported as percent of maximum), in percent of the reference or control that the assay uses: 34.8%
Compound 4: middle estimate off by 10.2 percentage points, on the high side; low and high end bracket the measured number.
By their numbers in this assay, from the lowest: compound 2; then compound 4; then compound 1; then compound 3.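

Notes on the propanoyl to acetyl change: in this assay this place proves sensitive on the core of compound 1, not only on the core of compound 2, with a number 27.7 percentage points lower from compound 1 to compound 4 (beyond the scatter). Removing a single carbon from the chain is therefore enough to move the maximal response beyond the scatter, and the sense of the change agrees with a number 92.7 percentage points higher from compound 2 to compound 3 (beyond the scatter): across these two pairs, the number is higher with the larger group on the saturated chain carbon bound to the carbonyl carbon, and neither pair goes against this, though two pairs on two different cores make only a narrow basis. Nothing on hand gives a measured reason for the change in maximal response at this place.

Going by these compounds, it remains open whether the gain seen with tert-butyl carries over to the core of compound 1, and whether the response on that core keeps rising with a longer chain such as butyl in place of ethyl or with a cyclopropyl ring at the same place. The effect of the other differences between the cores of compound 1 and compound 2 also stays unresolved, since these two compounds differ in more than one place.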